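One double bond, drawn the other way

This account rests on a few compounds, and the source may have more. Where it says the series, first, only, none or still open, it means among the compounds named here.

compound 1 `C/C(=N\NC(=S)Nc1ccc(Cl)cc1)c1ccccn1` gives 8.49 nM
compound 2 `C/C(=N/NC(=S)Nc1ccc([N+](=O)[O-])cc1)c1ccccn1` gives 52 nM

Both numbers come from a functional assay on MCF7 cells (Homo sapiens) for cytotoxicity, read by MTT assay, with a stated time of 48 h; a higher number here means a weaker inhibitor, a lower number a stronger inhibitor. Compound 2 has the higher number of the two (52 nM), so it is the weaker inhibitor, and its gap to compound 1 (8.49 nM) lies beyond the usual scatter of such measurements.

Compound 3 `C/C(=N\NC(=S)Nc1ccc([N+](=O)[O-])cc1)c1ccccn1` is compound 2 with a single change (the two compounds have the same atoms and bonds and differ only in configuration as drawn: 1 of 1 stereo elements differ; a double bond is drawn Z in compound 2 and E in compound 3). Nothing leaves and nothing enters: a double bond is drawn Z in compound 2 and E in compound 3. Within the data shown here, no measured pair shows a change of this kind, so any forecast is loose. A modest drop in this assay is expected, as compound 1 (8.49 nM) shows that lower numbers occur here, but no change beyond the scatter would also fit. The estimated step is a 2.1-fold lower number from compound 2 to compound 3 (0.32 log units; beyond the scatter), towards a stronger inhibitor. The estimate for compound 3 is 25 nM (range 6 nM to 110 nM).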

Compound 3, half-maximal inhibitory concentration: 52 nM
For compound 3 the middle estimate is 2.1-fold (0.32 log units) below the measured one; the measured number falls inside the stated range.
By their numbers in this assay, from the lowest: compound 1; then compounds 2 and 3 (each within the scatter of the next).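

In this assay, the step of no change at the digits printed from compound 2 to compound 3 (within the scatter) shows that, with nitro on the aromatic carbon, the way this double bond is drawn makes no visible difference to the number. The gap seen earlier between compound 1 and compound 2 combined two differences, whereas a single change can now be read: a 6.1-fold higher number from compound 1 to compound 3 (0.79 log units; beyond the scatter) for nitro in place of chloro on an aromatic carbon, with the double bond drawn the same way. That gap therefore follows the swap of chloro for nitro and not the drawing of the double bond, a reading that rests on one structural fact: the fact that compounds 2 and 3 differ only in the configuration as drawn.

The compounds shown leave open whether the double bond would be equally without effect with chloro on the aromatic carbon. They also leave open how an amine or a methoxy group there would compare.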